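From fluoromethyl to hydroxymethyl in a cytotoxicity series

The compounds below may be only part of what the source reports. "The series", "measured", "known", "first", "only" and "open" are said of these compounds alone.

Values measured in a functional assay on HeLa cells (Homo sapiens) for cytotoxicity, read by WST assay, with a stated time of 48 h (a lower number here means a stronger inhibitor, a higher number a weaker inhibitor), are these:
- Compound 1 `COc1cc(C(c2ccc(O)c(OC)c2)[C@H](C)[C@H](C)CO)ccc1O` gives > 100000 nM as a limit
- Compound 2 `COc1cc(C(c2ccc(O)c(OC)c2)[C@@H](CO)C(C)C)ccc1O` gives > 100000 nM as a limit
- Compound 3 `COc1cc(C(c2ccc(O)c(OC)c2)[C@@H](C)[C@H](C)CF)ccc1O` gives 37000 nM as a number

For the measured compounds named here, compound 3 holds the only actual number in this set (37000 nM). The other two readings are limits. Compound 4 `COc1cc(C(c2ccc(O)c(OC)c2)[C@H](C)[C@@H](C)CO)ccc1O` awaits measurement, and it differs from compound 3 by one change (2-(hydroxymethyl)-1-methylpropyl in place of 2-(fluoromethyl)-1-methylpropyl on a saturated chain carbon bound to two aromatic carbons): 2-(hydroxymethyl)-1-methylpropyl in place of 2-(fluoromethyl)-1-methylpropyl on a saturated chain carbon bound to two aromatic carbons.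

Going by the values given here, two measured steps bear on this change, and both run the opposite way. They are an at least 2.7-fold lower number from compound 1 to compound 3 (0.43 log units; beyond the scatter) and an at least 2.7-fold lower number from compound 2 to compound 3 (0.43 log units; beyond the scatter) and each gives only a lower bound on its size. Compound 1 carries the same 2-(hydroxymethyl)-1-methylpropyl group as compound 4, so the reverse of an at least 2.7-fold lower number from compound 1 to compound 3 (0.43 log units; beyond the scatter) is the closest guide. A higher number beyond the scatter is therefore expected in this assay on this change. The expected step is a 3.0-fold higher number from compound 3 to compound 4 (0.47 log units; beyond the scatter) and it may be larger. Compound 4 is expected quite possibly to end at the limit of > 100000 nM in this assay, at which 2 of the 3 values shown sit, and so give no number. The estimate for compound 4 is 110000 nM (expected range 60000 nM to 300000 nM).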

Compound 4, half-maximal inhibitory concentration: > 100000 nM
Compound 4: a limit, no number; the forecaster's own chance of this, stated with the estimate: 80%; the middle value lies beyond the limit too.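

Replacing 2-(fluoromethyl)-1-methylpropyl with 2-(hydroxymethyl)-1-methylpropyl on a saturated chain carbon bound to two aromatic carbons gives, in this assay, an at least 2.7-fold higher number from compound 3 to compound 4 (0.43 log units; beyond the scatter), so this direct comparison also points away from the hydroxymethyl group. All three hydroxymethyl compounds now give limits rather than numbers, and the steps from compound 1 and compound 2 to compound 4 cannot be read, so they cannot be ranked against one another: the limit of > 100000 nM in this assay, at which 3 of the 4 values shown sit. Compounds 1 and 4 form a direct pair for testing the stereocentre at a saturated chain carbon, yet they give no readable difference in this assay, which is the new point about configuration here: the fact that compounds 1 and 4 differ only in the configuration as drawn.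

Going by these compounds, how far the number of compound 3 stands from the true values of the hydroxymethyl compounds remains open, as does whether the configuration matters for the fluoromethyl group. On these data alone, it is also open how an amine, a carboxylic acid or a longer chain in place of the fluorine would read in this assay.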